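The source may report more compounds than this note shows. Statements on the series, on what has been measured and on what is new or still open speak of the compounds shown alone.

In an assay on isolated protein for inhibition of matrix metalloproteinase-9 (Homo sapiens) (on this read-out lower numbers stand for stronger inhibition and higher numbers for weaker inhibition), compound 3 `O=C(OCc1cccc(F)c1)c1cccc(=O)[nH]1` gives 50000 nM. Compound 2 `O=C(OCc1cccc(Cl)c1)c1cccc(=O)[nH]1` gives 67000 nM, and compound 1 `O=C(OCc1ccccc1)c1cccc(=O)[nH]1` gives 69000 nM. The steps of a 1.4-fold lower number from compound 1 to compound 3 (0.14 log units; within the scatter) and a 1.3-fold lower number from compound 2 to compound 3 (0.13 log units; within the scatter) both fall within the usual scatter, so the three compounds stand together rather than apart. Compound 4 `O=C(OCc1cccc(C(F)(F)F)c1)c1cccc(=O)[nH]1` differs from compound 3 by trifluoromethyl in place of fluoro on an aromatic carbon. Among the measured compounds shown here, the steps that bear on this are the ones that changed the same aromatic carbon: a 1.0-fold lower number from compound 1 to compound 2 (0.01 log units; within the scatter), a 1.4-fold lower number from compound 1 to compound 3 (0.14 log units; within the scatter) and a 1.3-fold lower number from compound 2 to compound 3 (0.13 log units; within the scatter), none of them beyond the scatter. On that basis compound 4 is expected to give a number close to that of compound 3, with the step of no change at the digits printed from compound 3 to compound 4 (within the scatter) estimated to stay within the scatter. Compound 4 is therefore estimated at 50000 nM, with a range from 25000 nM to 100000 nM.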

Compound 4, half-maximal inhibitory concentration: > 150 nM
Compound 4 ended at the assay's limit; the forecaster's own chance of this, stated with the estimate: 10%; the middle value lies beyond the limit too.
By their numbers in this assay, from the lowest: compounds 3, 2 and 1 (each within the scatter of the next).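

In this assay, among the compounds shown here, compound 4 gives > 150 nM, which is a limit of the assay and not a number, so no step from compound 1, compound 2 or compound 3 to compound 4 can be read. The compounds shown leave open whether trifluoromethyl on that aromatic carbon changes the number at all.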